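The source may report more compounds than this note shows. Statements on the series, on what has been measured and on what is new or still open speak of the compounds shown alone.

Compound 2 `CCCS(=O)(=O)Nc1ccc(F)c(C(=O)c2n[nH]c3ncc(-c4ccc(F)cc4)cc23)c1F` gives 2.1% in an assay for binding affinity to dual specificity mitogen-activated protein kinase kinase 4 (Homo sapiens), read by KINOMEscan, tested at 100 nM (on this read-out lower numbers stand for a stronger effect and higher numbers for a weaker effect at the one concentration tested), the lowest of the three numbers in hand, though every gap to the others stays within the scatter. Compound 1 `CCCS(=O)(=O)Nc1ccc(F)c(C(=O)c2n[nH]c3ncc(-c4ccccc4Cl)cc23)c1F` gives 9.3% in this assay, and the change a number 7.2 percentage points lower from compound 1 to compound 2 (within the scatter) is within the scatter. Compound 3 `CCCS(=O)(=O)Nc1ccc(F)c(C(=O)c2n[nH]c3ncc(-c4ccc(OC)cc4Cl)cc23)c1F` gives 5.3% in this assay; the steps of a number 4 percentage points lower from compound 1 to compound 3 (within the scatter) and a number 3.2 percentage points higher from compound 2 to compound 3 (within the scatter) are likewise within the scatter. Across this small set, exchange of the aryl substituents has left the read-out essentially unchanged.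

Compound 4 `CCCS(=O)(=O)Nc1ccc(F)c(C(=O)c2n[nH]c3ncc(-c4ccc(S(=O)(=O)NC(C)=O)cc4)cc23)c1F` is not yet measured. It differs from compound 2 by acetylsulfamoyl in place of fluoro on an aromatic carbon. Among the measured compounds shown here, none of the measured steps introduces a group of this size or with a hydrogen-bond donor at that position, so they bear on the new change only loosely; what they do show is that three varied aryl substituents all landed within the scatter of one another. On that basis the expected step is a number 3.9 percentage points higher from compound 2 to compound 4 (within the scatter), with no clear direction beyond the scatter, but with wider uncertainty than for the measured pairs given the larger group entering. Compound 4 is therefore estimated at 6% in this assay, with a range from 1% to 30%.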

Compound 4, a percentage reported as activity, at one concentration (the size of the read-out at that concentration, not a potency): 0.35%
Estimate against measurement, compound 4: 5.7 percentage points above; measured number below the stated range.
By their numbers in this assay, from the lowest: compounds 4, 2, 3 and 1 (each within the scatter of the next).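

In this assay, the position para to a large group accepts acetylsulfamoyl in place of fluoro with a number 1.8 percentage points lower from compound 2 to compound 4 (within the scatter). The earlier compounds shown here varied only small substituents on this aryl ring, whereas this change brings in a far larger group with a hydrogen-bond donor and hydrogen-bond acceptors, and the read-out stays within the scatter of compound 2. No supporting data bear on why the read-out holds at this position.

As far as these compounds go, whether an amine, a carboxylic acid or a longer chain at this position would also stay within the scatter remains open, as does whether a plain sulfamoyl would behave like acetylsulfamoyl. With one concentration and all of these steps within the scatter, the compounds shown do not rank the substituents.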